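Trimming an ethyl chain to methyl near the limit

The compounds below may be only part of what the source reports. "The series", "measured", "known", "first", "only" and "open" are said of these compounds alone.

Compound 1 `CC(C)n1nc(-c2ccnc3[nH]c(C4CCN(CC(=O)N(C)C)CC4)cc23)ccc1=O`: 11000 nM
Compound 2 `CC(C)Cn1cc(-c2ccnc3[nH]c(C4CCN(CC(=O)N(C)C)CC4)cc23)ccc1=O`: 390000 nM
Compound 3 `CCn1cc(-c2ccnc3[nH]c(C4CCN(CC(=O)N(C)C)CC4)cc23)ccc1=O`: > 1000000 nM

In a physicochemical assay for solubility, in phosphate buffer, at pH 7.4 (a lower number here means a less soluble compound, a higher number a more soluble compound), compound 3 gives > 1000000 nM, which is a limit and not a number. It stands highest of the three, and two measured steps lead up to it. One is an at least 90-fold higher number from compound 1 to compound 3 (1.95 log units; beyond the scatter), a change in the ring. Closer to the case here is an at least 2.5-fold higher number from compound 2 to compound 3 (0.40 log units; beyond the scatter), a change at the same place. Compound 4 `CN(C)C(=O)CN1CCC(c2cc3c(-c4ccc(=O)n(C)c4)ccnc3[nH]2)CC1` shortens that chain again, ethyl to methyl: hydrogen in place of methyl on a saturated chain carbon bound to an aromatic nitrogen. The estimated change is a step that the limit leaves unreadable from compound 3 to compound 4, a modest rise or none beyond the scatter. For compound 4 the expected value is 1500000 nM, with an estimated range from 600000 nM to 4000000 nM.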

Compound 4, solubility: > 1000000 nM
Compound 4: a limit, no number (the forecaster's own chance of this, stated with the estimate: 75%); the middle value is on the limit's open side.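

In this assay compound 4 gives > 1000000 nM, which is a limit and not a number. Hydrogen in place of methyl at this place keeps the value at that limit, with an at least 2.5-fold higher number from compound 2 to compound 4 (0.40 log units; beyond the scatter) and an at least 90-fold higher number from compound 1 to compound 4 (1.95 log units; beyond the scatter). The step between compound 3 and compound 4 cannot be read, because both sit at the same ceiling: the limit of > 1000000 nM in this assay, at which 2 of the 4 values shown sit.

Going by these compounds, whether compound 3 and compound 4 differ at all stays open. So does how a propyl chain, or a chain ending in an amine, would compare at this place.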